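Removing both chloro groups: from compound 3 to compound 4

A few compounds are considered here, and "the series" means these few. Any claim that something is new, unique, unknown or untested is made for them only; others in the source may bear on it.

In a functional assay on cells (T-cell line, Homo sapiens) for inhibition (a lower number here means a stronger inhibitor, a higher number a weaker inhibitor), compound 1 (`COc1ccc(CCCN2CCC(COCc3ccccc3)CC2)cc1`) gives 2100 nM, compound 2 (`COc1ccc(CCCN2CCC(COCc3ccc(Cl)cc3)CC2)cc1`) gives 500 nM, and compound 3 (`COc1ccc(CCCN2CCC(COCc3ccc(Cl)c(Cl)c3)CC2)cc1`) gives 200 nM, the lowest number of the three. Compound 4 (`COc1ccc(CCCN2CCC(COCc3ccccn3)CC2)cc1`) carries pyridin-2-yl in place of 3,4-dichlorophenyl on a saturated chain carbon bound to an oxygen on a saturated carbon. Among the measured compounds shown here, three measured steps bear on this: a 4.2-fold lower number from compound 1 to compound 2 (0.62 log units; beyond the scatter), then a 2.5-fold lower number from compound 2 to compound 3 (0.40 log units; beyond the scatter), and overall an 11-fold lower number from compound 1 to compound 3 (1.02 log units; beyond the scatter). Each added chloro lowered the number, and compound 4 has none, like compound 1 at 2100 nM. For the measured compounds named here, no measured compound carries pyridin-2-yl, so that part remains unknown. A large rise is therefore expected, an 18-fold higher number from compound 3 to compound 4 (1.24 log units; beyond the scatter). For compound 4 the estimated value is 3500 nM, with an expected range of 1200 nM to 10000 nM.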

Compound 4, half-maximal inhibitory concentration: 5900 nM
Beside the measured number, compound 4's estimate is 1.7-fold (0.23 log units) below it; measured number inside the range.
By their numbers in this assay, from the lowest: compound 3; then compound 2; then compound 1; then compound 4.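

In this assay, the ring on this saturated chain carbon matters beyond its chloro groups: pyridin-2-yl loses far more than the chloro gains (a 30-fold higher number from compound 3 to compound 4 (1.47 log units; beyond the scatter); a 12-fold higher number from compound 2 to compound 4 (1.07 log units; beyond the scatter)). Even the plain phenyl ring, with no chloro, gives a lower number than pyridin-2-yl (a 2.8-fold higher number from compound 1 to compound 4 (0.45 log units; beyond the scatter)), so a ring nitrogen in place of a ring carbon is not a neutral swap here. Nothing available gives a reason for these steps.

As far as these compounds go, whether a chloro on pyridin-2-yl would lower the number, as it did on phenyl, remains open. So does how pyridin-3-yl or pyridin-4-yl would compare.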